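Methyl in Place of Trifluoromethyl on Two Related Cores

The compounds below may be only part of what the source reports. "The series", "measured", "known", "first", "only" and "open" are said of these compounds alone.

Three compounds were measured in a functional assay on KB 3-1 cells (Homo sapiens) for cytotoxicity, read by MTT assay, with a stated time of 68 h; a lower number here means a stronger inhibitor, a higher number a weaker inhibitor:

compound 1, `O=C(Nc1cccc(-c2ccccc2C(F)(F)F)c1)C(Cl)Cl`: 35900 nM
compound 2, `Cc1ccccc1-c1cccc(NC(=O)C(Cl)Cl)c1`: 42000 nM
compound 3, `O=C(Nc1cccc(-c2cccc(C(F)(F)F)c2)c1)C(Cl)Cl`: > 50000 nM

For compound 3 the value is only a limit of this assay, (the limit of > 50000 nM in this assay, at which 1 of the 3 values shown sits). Compound 1 and compound 2 differ by methyl in place of trifluoromethyl on an aromatic carbon, and this change gave a 1.2-fold higher number from compound 1 to compound 2 (0.07 log units; within the scatter). The difference between the core of compound 1 and the core of compound 3 is not broken down here.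

Compound 4, `Cc1cccc(-c2cccc(NC(=O)C(Cl)Cl)c2)c1`, differs from compound 3 by methyl in place of trifluoromethyl on an aromatic carbon. It is the same kind of change as that from compound 1 to compound 2, but the group leaves a place meta to a large group rather than ortho to a large group. Since compound 3 sits at the limit and the earlier step was within the scatter, compound 4 is expected to stay weak, with an estimated step that the limit leaves unreadable from compound 3 to compound 4 in this assay. The estimate for compound 4 is 60000 nM, between 30000 nM and 150000 nM.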

Compound 4, half-maximal inhibitory concentration: > 50000 nM
Compound 4 was reported as a limit; the forecaster's own chance of this, stated with the estimate: 60%; the middle value lies beyond the limit too.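

Compound 3 and compound 4 both stand only as limits in this assay, so no step between them can be read: the limit of > 50000 nM in this assay, at which 2 of the 4 values shown sit.

The compounds shown leave open whether methyl in place of trifluoromethyl changes the number at this place.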